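A few compounds are considered here, and "the series" means these few. Any claim that something is new, unique, unknown or untested is made for them only; others in the source may bear on it.

Compound 1 `CCCCCCCN1CCC(C(=O)Nc2cc(Cl)c(N)cc2OC)CC1`: > 10 mg/kg
Compound 2 `COc1cccc(CN2CCC(C(=O)Nc3cc(Cl)c(N)cc3OC)CC2)c1`: > 4 mg/kg

In a functional assay on the whole organism for antagonist activity, with Mus musculus as the target (a lower number here means that less compound is needed, a higher number that more compound is needed for the effect), compound 1 gives only a limit, > 10 mg/kg. In this assay compound 2 also gives only a limit, > 4 mg/kg. Among the compounds with values here, the one measured step, a step that the two limits leave unreadable from compound 1 to compound 2, therefore has no readable size. Compound 3 `COc1cc(N)c(Cl)cc1NC(=O)C1CCN(Cc2ccc(O)cc2)CC1` differs from compound 2 by 4-hydroxyphenyl in place of 3-methoxyphenyl on a saturated chain carbon bound to an amine nitrogen in a ring. Within the data shown here, no measured step covers this change, and with compound 2 standing only at a limit, no step beyond the scatter is expected in this assay. Compound 3 is expected to give 8 mg/kg, between 3 mg/kg and 30 mg/kg. The expected step is a step that the limit leaves unreadable from compound 2 to compound 3.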

Compound 3, dose for half-maximal effect: > 8 mg/kg
Compound 3 gave a limit, no number; the forecaster's own chance of this, stated with the estimate: 70%; the middle value sits exactly at the limit.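

In this assay, within the data shown here, compound 1, compound 2 and compound 3 all give only limits, not numbers, so no step among them can be read. The compounds shown leave open what dose of each is needed, and whether hexyl, 3-methoxyphenyl or 4-hydroxyphenyl makes any difference.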